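The compounds below may be only part of what the source reports. "The series", "measured", "known", "first", "only" and "open" are said of these compounds alone.

Working notes on the series. Among the compounds with values here, in an assay on a cell-free system (plasma) for inhibition of lysosomal Pro-X carboxypeptidase (Mus musculus) (a higher number here means a weaker inhibitor, a lower number a stronger inhibitor), compound 2 `O=C(CCN1CCC(c2nc(-c3cnccn3)no2)CC1)N1CCC[C@H]1c1nc2cc(Cl)c(Cl)cc2[nH]1` gives 435 nM, the upper of only two numbers so far, yet within the scatter of compound 1 `O=C(CCN1CCC(c2cc[nH]n2)CC1)N1CCC[C@H]1c1nc2cc(Cl)c(Cl)cc2[nH]1`, which in this assay gives 290 nM; the single measured step is a 1.5-fold higher number from compound 1 to compound 2 (0.18 log units; within the scatter). Compound 3 `O=C(CCN1CCC(c2cc(-c3ccncc3)[nH]n2)CC1)N1CCC[C@H]1c1nc2cc(Cl)c(Cl)cc2[nH]1` carries a group of 11 heavy atoms (8 carbon, 3 nitrogen; one five-membered aromatic ring with 2 hetero atoms, one six-membered aromatic ring with 1 hetero atom) in place of a group of 11 heavy atoms (6 carbon, 4 nitrogen, 1 oxygen; one five-membered aromatic ring with 3 hetero atoms, one six-membered aromatic ring with 2 hetero atoms), on a saturated ring carbon. Within the data shown here, the one step that bears on this exchange, a 1.5-fold higher number from compound 1 to compound 2 (0.18 log units; within the scatter), swapped a five-membered aromatic ring with 2 hetero atoms for the larger group now leaving, and stayed within the scatter. The entering 5-(pyridin-4-yl)-1H-pyrazol-3-yl again holds a five-membered aromatic ring with 2 hetero atoms and 1 hydrogen-bond donor, as compound 1 does, so no step beyond the scatter is expected in this assay. Compound 3 is therefore estimated at 330 nM, between 150 nM and 750 nM, which means an expected step of a 1.3-fold lower number from compound 2 to compound 3 (0.12 log units; within the scatter).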

Compound 3, half-maximal inhibitory concentration: 485 nM
The estimate for compound 3 lay 1.5-fold (0.17 log units) below the measured number; measured number inside the range.
By their numbers in this assay, from the lowest: compounds 1, 2 and 3 (each within the scatter of the next).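

In this assay, exchanging the two large groups on this saturated ring carbon gives a 1.1-fold higher number from compound 2 to compound 3 (0.05 log units; within the scatter), so a five-membered aromatic ring with 2 hetero atoms and one with 3 hetero atoms, each carrying a six-membered aromatic ring, cannot be told apart here. Within the data shown here, the new compound also gives the first step on the pyrazole itself, pyridin-4-yl in place of hydrogen on an aromatic carbon, with a 1.7-fold higher number from compound 1 to compound 3 (0.22 log units; within the scatter), so this added ring leaves the number within the scatter. No measurement offers an explanation for these results.

The compounds shown leave open whether any group on this saturated ring carbon can move the number beyond the scatter. A carboxylic acid or an amine on that same aromatic carbon, or a phenyl ring in place of pyridin-4-yl, would test this.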